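Pyridin-2-yl in place of methyl on a nitrogen

The source may report more compounds than this note shows. Statements on the series, on what has been measured and on what is new or still open speak of the compounds shown alone.

Measured so far in a functional assay on HL-60 cells (Homo sapiens) for cytotoxicity, read by MTT assay, with a stated time of 3 days; on this read-out higher numbers stand for weaker inhibition and lower numbers for stronger inhibition:
- compound 1 `N#Cc1c(O)nc(SCc2nc3ccccc3[nH]2)nc1-c1ccccc1` gives 2.55 nM
- compound 2 `N#Cc1c(Nc2ccccc2)nc(SCc2nc3ccccc3[nH]2)nc1-c1ccccc1` gives 4.46 nM
- compound 3 `CNc1nc(SCc2nc3ccccc3[nH]2)nc(-c2ccccc2)c1C#N` gives 6.57 nM

Among the measured compounds shown here, only one gap around compound 3 lies beyond the scatter (a 2.6-fold higher number from compound 1 to compound 3 (0.41 log units; beyond the scatter)). Compound 4 `N#Cc1c(Nc2ccccn2)nc(SCc2nc3ccccc3[nH]2)nc1-c1ccccc1` has pyridin-2-yl in place of methyl on a nitrogen on an aromatic ring. The closest guide is compound 2, which also carries a six-membered aromatic ring on that nitrogen. Its change to methyl stayed within the scatter (a 1.5-fold higher number from compound 2 to compound 3 (0.17 log units; within the scatter)), so only a small shift is expected in this assay, with no step beyond the scatter. The expected change is small (a 1.5-fold lower number from compound 3 to compound 4 (0.16 log units; within the scatter)). For compound 4 the estimated value is 4.5 nM with an expected range of (2 nM to 10 nM).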

Compound 4, half-maximal inhibitory concentration: 20 nM
The estimate for compound 4 lay 4.4-fold (0.65 log units) below the measured number; measured number above the stated range.
By their numbers in this assay, from the lowest: compounds 1, 2 and 3 (each within the scatter of the next, the first and the last beyond it); then compound 4.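

In this assay, among the compounds shown here, the swap gives a 3.0-fold higher number from compound 3 to compound 4 (0.48 log units; beyond the scatter) and is the first change on this nitrogen to pass the scatter. One ring nitrogen separates pyridin-2-yl from phenyl, yet that exchange gives a 4.5-fold higher number from compound 2 to compound 4 (0.65 log units; beyond the scatter) here, so the ring's make-up counts, not just the presence of a six-membered aromatic ring. Replacing hydroxy with (pyridin-2-yl)amino gives a 7.8-fold higher number from compound 1 to compound 4 (0.89 log units; beyond the scatter) as the widest step in this set.

Nothing available explains the loss. Going by these compounds, whether other groups on that nitrogen, such as cyclohexyl or thienyl, track phenyl or pyridin-2-yl stays open.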